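A few compounds are considered here, and "the series" means these few. Any claim that something is new, unique, unknown or untested is made for them only; others in the source may bear on it.

Compound 1 `C=CCOC(=O)/C=C(C)/C=C/CC(C)CCCC(C)C` is the most lipophilic of the three measured compounds: in a physicochemical assay for lipophilicity (a higher number here means a more lipophilic compound, a lower number a more polar compound), compound 1 gives 6.73, compound 3 `C/C=C/COC(=O)/C=C(C)/C=C/CC(C)CCCC(C)(C)OC` gives 6.07, and compound 2 `C=CCOC(=O)/C=C(C)/C=C/CC(C)CCCC(C)(C)OC` gives 5.53. Compound 4 `CC(/C=C/CC(C)CCCC(C)C)=C\C(=O)CC(C)C` differs from compound 1 in one place: isobutyl in place of allyloxy on a carbonyl carbon. Among the measured compounds shown here, no measured step matches this change. The nearest guides are a number 1.20 log units lower from compound 1 to compound 2 (beyond the scatter), where adding an oxygen lowered the number, and a number 0.54 log units higher from compound 2 to compound 3 (beyond the scatter), where adding a carbon raised it; compound 4 loses an oxygen and keeps the carbon count, so a rise beyond the scatter is expected. The estimated step is a number 0.67 log units higher from compound 1 to compound 4 (beyond the scatter). For compound 4 the expected value in this assay is 7.4, with a likely range from 6.9 to 7.9.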

Compound 4, partition coefficient: 7.22
Estimate against measurement, compound 4: 0.18 log units above; the range from low to high includes it.
By their numbers in this assay, from the lowest: compound 2; then compound 3; then compound 1; then compound 4.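

On a carbonyl carbon, isobutyl in place of allyloxy gives a number 0.49 log units higher from compound 1 to compound 4 (beyond the scatter) in this assay. Among the compounds shown here, this is the first measured change at this carbonyl carbon, and it shows that the number can move there while the count of heavy atoms stays the same, with one hydrogen-bond acceptor leaving and none entering. Nothing available explains why the number moves. On these data alone, what an amine or a longer chain on this carbonyl carbon would do remains open, as does whether the same swap gives a similar step in compound 2, which carries methoxy.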